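Halogenated benzyl thioethers on the shared core: step to compound 3

The source may report more compounds than this note shows. Statements on the series, on what has been measured and on what is new or still open speak of the compounds shown alone.

Measured compounds:
- compound 1, `COc1cc(-c2nnc(SCc3ccc(F)cc3F)o2)ccc1O` — 9690 nM
- compound 2, `COc1cc(-c2nnc(SCc3ccccc3Br)o2)ccc1O` — 17800 nM

Both compounds share a core that differs only in the aryl group on the saturated chain carbon bound to a sulfur. In a functional assay on cells (T-cell, Mus musculus, strain BALB/c) for inhibition, read by MTT assay, with stated times of 24 h and 72 h (a higher number here means a weaker inhibitor, a lower number a stronger inhibitor), compound 1 gives 9690 nM and compound 2 gives 17800 nM. The step of a 1.8-fold higher number from compound 1 to compound 2 (0.26 log units; within the scatter) is the only one measured, and it lies within the scatter, so compound 2 cannot be set apart from compound 1 on these numbers; it merely carries the higher of the two.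

Compound 3, `COc1cc(-c2nnc(SCc3ccc(F)cc3)o2)ccc1O`, is not yet measured. Its change from compound 2 is 4-fluorophenyl in place of 2-bromophenyl on a saturated chain carbon bound to a sulfur. Going by the values given here, this is the same place and the same kind of swap of one halogenated phenyl for another as in the single measured step, and because a 1.8-fold higher number from compound 1 to compound 2 (0.26 log units; within the scatter) stayed within the scatter, no step beyond the scatter is expected in this assay here either. Compound 3 is therefore estimated at 12000 nM in this assay, with a range of 5000 nM to 30000 nM, which means an expected step of a 1.5-fold lower number from compound 2 to compound 3 (0.17 log units; within the scatter).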

Compound 3, half-maximal inhibitory concentration: 8190 nM
Compound 3: the middle estimate sits 1.5-fold (0.17 log units) above what was measured, and the stated range covers the measured number.
By their numbers in this assay, from the lowest: compounds 3, 1 and 2 (each within the scatter of the next, the first and the last beyond it).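

In this assay, going by these compounds alone, 4-fluorophenyl in place of 2-bromophenyl on a saturated chain carbon bound to a sulfur gives the first step that lies beyond the scatter, though a modest one (a 2.2-fold lower number from compound 2 to compound 3 (0.34 log units; beyond the scatter)), so the choice of aryl group at this place can register in the read-out. Hydrogen in place of fluoro on an aromatic carbon stays within the scatter (a 1.2-fold lower number from compound 1 to compound 3 (0.07 log units; within the scatter)), so 2,4-difluorophenyl and 4-fluorophenyl cannot be told apart here, and compound 2 is set apart from compound 3 only, not from compound 1. Nothing available bears on the reason for the step from 2-bromophenyl to 4-fluorophenyl.

Bromine and its place on the ring change together in that step, so it remains open whether 4-bromophenyl or 2-fluorophenyl would follow the halogen or its place on the ring. Also open, as far as these compounds go, is how far the number would move with an amine or a carboxylic acid on the phenyl ring, or with a longer chain on the sulfur in place of the single saturated carbon.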